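Three Compounds at the Limit, a Fourth Expected There

The compounds below may be only part of what the source reports. "The series", "measured", "known", "first", "only" and "open" are said of these compounds alone.

Compound 3 `COc1cccc(CNc2ncnc3c2ncn3[C@@H]2O[C@H](CO)[C@@H](O)[C@H]2O)c1` was examined in an ADME assay on NIH3T3 cells (Mus musculus) for cytotoxicity, with a stated time of 72 h; a higher number here means a weaker inhibitor, a lower number a stronger inhibitor. In that assay compound 3 gives > 166000 nM, which is a limit of the assay and not a number. The two companions stand the same way. Compound 1 `OC[C@H]1O[C@@H](n2cnc3c(NCc4ccccc4F)ncnc32)[C@H](O)[C@@H]1O` gives > 166000 nM in this assay, again a limit of the assay. Compound 2 `OC[C@H]1O[C@@H](n2cnc3c(NCc4ccc(Cl)cc4)ncnc32)[C@H](O)[C@@H]1O` gives > 166000 nM in this assay, also a limit of the assay. Compound 3 therefore stands level with both others as far as the numbers reach, all three sitting at the limit of > 166000 nM in this assay, at which 3 of the 3 values shown sit.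

Compound 4 `OC[C@H]1O[C@@H](n2cnc3c(NCc4ccc(F)cc4F)ncnc32)[C@H](O)[C@@H]1O` has not yet been measured. It differs from compound 3 in one place: 2,4-difluorophenyl in place of 3-methoxyphenyl on a saturated chain carbon bound to a nitrogen on an aromatic ring. The measured steps that touch the same position are a step that the two limits leave unreadable from compound 1 to compound 2, a step that the two limits leave unreadable from compound 1 to compound 3 and a step that the two limits leave unreadable from compound 2 to compound 3, and none of them has a readable size. Among the measured compounds shown here, no measured step thus points in a direction for the new exchange. The account expects compound 4 to return a limit as well, with a number no higher from compound 3 to compound 4 (the limit leaves the size open) expected to be nothing beyond the scatter. Compound 4 is estimated at 166000 nM, within 80000 nM to 400000 nM.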

Compound 4, half-maximal inhibitory concentration: > 166000 nM
Compound 4 was reported as a limit; the forecaster's own chance of this, stated with the estimate: 85%; the middle value lies on the limit itself.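

Compound 4 joins compound 1, compound 2 and compound 3 at a limit, not a number, in this assay, so none of its steps to them can be read: the limit of > 166000 nM in this assay, at which 4 of the 4 values shown sit.

The compounds shown leave open how these four differ beyond that limit, and whether any exchange at this place would give a measurable value.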